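The compounds below may be only part of what the source reports. "The series", "measured", "known", "first", "only" and "open" are said of these compounds alone.

Compound 1 `COc1ccc(C2N=C(SCc3ccccc3)NC(C)=C2C(=O)Nc2ccc(F)cc2)cc1OC` gives 3.1% in a functional assay on the whole organism (artery, strain albino) with Rattus norvegicus as the target, with a stated time of 600 min, at a dose of 10 mg/kg by the oral route; a higher number here means more inhibition at the dose given (going by the name of the read-out), a lower number less inhibition. Compound 2 `COc1ccc(C2N=C(SCc3cccc(Cl)c3)NC(C)=C2C(=O)Nc2ccc(F)cc2)cc1OC` gives 17.4%. Compound 3 `CC1=C(C(=O)Nc2ccc([N+](=O)[O-])cc2)C(c2cccc([N+](=O)[O-])c2)N=C(SCc2ccccc2)N1` gives 27.2%.

Compound 2 differs from compound 1 by chloro in place of hydrogen on an aromatic carbon, and this step is a number 14.3 percentage points higher from compound 1 to compound 2 (beyond the scatter). Compound 3 rests on a different core; the difference between the two cores is not broken down here. The values of compound 3 and compound 2 lie within the scatter of each other, while compound 3 lies beyond the scatter above compound 1.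

Compound 4 `CC1=C(C(=O)Nc2ccc([N+](=O)[O-])cc2)C(c2cccc([N+](=O)[O-])c2)N=C(SCc2ccccc2Cl)N1` differs from compound 3 by chloro in place of hydrogen on an aromatic carbon. Here the chloro sits ortho to a large group, whereas in compound 2 it sits meta to a large group, so this is the same kind of change, not the same one. The step from compound 3 to compound 4 is expected to be a number 8.8 percentage points higher from compound 3 to compound 4 (within the scatter), because the earlier step of this kind was a number 14.3 percentage points higher from compound 1 to compound 2 (beyond the scatter), though the place differs. Compound 4 is therefore estimated at 36%.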

Compound 4, a percentage reported as inhibition, in the whole organism at one dose (the size of the read-out at that dose, not a potency): 13.3%
Estimate against measurement, compound 4: 22.7 percentage points above; measured number below the stated range.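

In this assay, chloro in place of hydrogen on an aromatic carbon gives a number 13.9 percentage points lower from compound 3 to compound 4 (beyond the scatter). Carried from one core to the other, this change did not keep its direction: the same change on two cores in this assay, a number 14.3 percentage points higher (beyond the scatter) from compound 1 to compound 2 and a number 13.9 percentage points lower (beyond the scatter) from compound 3 to compound 4, 28.2 percentage points apart, beyond the scatter of two such steps. This does not show whether the core or the place of the chloro decides the outcome, as the two pairs differ in both: in compound 4 the chloro sits ortho to a large group, and in compound 2 it sits elsewhere.

The compounds shown leave open how a chloro at one and the same place would behave on both cores. They also leave open whether an amine or a carboxylic acid on the benzyl group would follow either step.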